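Aryl swap on the shared core: compound 1 to compound 4

This account rests on a few compounds, and the source may have more. Where it says the series, first, only, none or still open, it means among the compounds named here.

Numbers so far in a functional assay on BMDM cells (Mus musculus, strain C57BL/6) for inhibition, with a stated time of 2 days; on this read-out lower numbers stand for stronger inhibition and higher numbers for weaker inhibition:
Compound 1 `Cc1csc(NC(=O)Cn2cc(-c3cccc(N)c3)nn2)n1` gives 250 nM.
Compound 2 `Nc1cccc(-c2cn(CC(=O)Nc3nccs3)nn2)c1` gives 1270 nM.
Compound 3 `COC(=O)c1ccc(-c2cn(CC(=O)Nc3cc(C)on3)nn2)cc1` gives only a limit of the assay, > 30000 nM.

Compound 1 holds the lowest of the two numbers; the nearest neighbour sits at a 5.1-fold higher number from compound 1 to compound 2 (0.71 log units; beyond the scatter), the change being hydrogen in place of methyl on an aromatic carbon. Compound 4 `Cc1csc(NC(=O)Cn2cc(-c3ccc(Cl)cc3)nn2)n1` differs from compound 1 by 4-chlorophenyl in place of 3-aminophenyl on an aromatic carbon. Within the data shown here, no measured step touches this group or this position; the single measured step concerns a different part of the shared core. Compound 3 carries yet another aryl group with a different amide partner and reaches only (the limit of > 30000 nM in this assay, at which 1 of the 3 values shown sits). The expectation for compound 4 is therefore wide, allowing a modest weakening. A step of a 3.2-fold higher number from compound 1 to compound 4 (0.51 log units; beyond the scatter) is expected. Compound 4 is thus estimated at 800 nM, between 150 nM and 5000 nM.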

Compound 4, half-maximal inhibitory concentration: 520 nM
The estimate for compound 4 lay 1.5-fold (0.19 log units) above the measured number; the range from low to high includes it.
By their numbers in this assay, from the lowest: compound 1; then compound 4; then compound 2. At a limit, above all of these: compound 3.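

Among these compounds, the first measured change at this aromatic carbon of the five-membered ring, 4-chlorophenyl in place of 3-aminophenyl, gives a 2.1-fold higher number from compound 1 to compound 4 (0.32 log units; beyond the scatter) in this assay as a modest step. The 3-aminophenyl group is therefore not required for a measurable number here, even though the entering group counts 0 hydrogen-bond donors and 0 hydrogen-bond acceptors. Among the compounds shown here, nothing measured so far accounts for the step.

Still open, as far as these compounds go, is whether the step belongs to the change of substituent or to its place on the phenyl ring. A 3-chlorophenyl or 4-aminophenyl group on the core of compound 1 would separate the two.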